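Methyl for trifluoromethyl: compound 3 to compound 4

The compounds below may be only part of what the source reports. "The series", "measured", "known", "first", "only" and "open" are said of these compounds alone.

Compound 3 `NC(=O)c1c(NC(=O)c2ccccc2C(F)(F)F)sc2c1CCN(C(=S)Nc1ccccc1Br)C2` gives 25500 nM in a functional assay on HL-60 cells (Homo sapiens) for antiproliferative activity, with a stated time of 24 h (a higher number here means a weaker inhibitor, a lower number a stronger inhibitor), the highest of the three numbers shown, although compound 1 `Cc1ccccc1C(=O)Nc1sc2c(c1C(N)=O)CCN(C(=S)Nc1ccccc1Cl)C2` at 20900 nM and compound 2 `NC(=O)c1c(NC(=O)c2ccccc2I)sc2c1CCN(C(=S)Nc1ccccc1Br)C2` at 18900 nM both sit within the scatter of it. Compound 4 `Cc1ccccc1C(=O)Nc1sc2c(c1C(N)=O)CCN(C(=S)Nc1ccccc1Br)C2` differs from compound 3 by methyl in place of trifluoromethyl on an aromatic carbon. Among the measured compounds shown here, the one measured step at that position, a 1.3-fold higher number from compound 2 to compound 3 (0.13 log units; within the scatter), stayed within the scatter. For the measured compounds named here, no measured pair isolates methyl against trifluoromethyl; compound 1, which carries the methyl, and compound 3 show values within the scatter of each other. The expected step in this assay is therefore a 1.2-fold lower number from compound 3 to compound 4 (0.08 log units; within the scatter), nothing beyond the scatter. Compound 4 is estimated at 21000 nM in this assay, with a range of 10000 nM to 45000 nM.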

Compound 4, half-maximal inhibitory concentration: 45200 nM
Estimate against measurement, compound 4: 2.2-fold (0.33 log units) below, outside the stated range (above it).
By their numbers in this assay, from the lowest: compounds 2, 1, 3 and 4 (each within the scatter of the next, the first and the last beyond it).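

In this assay, among the compounds shown here, methyl in place of iodo gives a 2.4-fold higher number from compound 2 to compound 4 (0.38 log units; beyond the scatter), the first step at this position to pass the scatter, while methyl in place of trifluoromethyl gives a 1.8-fold higher number from compound 3 to compound 4 (0.25 log units; within the scatter). With the methyl kept, bromo in place of chloro gives a 2.2-fold higher number from compound 1 to compound 4 (0.33 log units; beyond the scatter), so a change elsewhere on the molecule also passes the scatter, if modestly. No evidence on the cause of these steps is available.

Open, on these data alone, is whether an amine or a carboxylic acid at this position would give a lower number than iodo. Also open, as far as these compounds go, is whether the bromo for chloro step holds with iodo or trifluoromethyl in place of the methyl.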